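A bromothiophene in place of a bromopyridine

The source may report more compounds than this note shows. Statements on the series, on what has been measured and on what is new or still open speak of the compounds shown alone.

In an ADME assay on A549 cells (Homo sapiens) for cytotoxicity, read by resazurin assay, with a stated time of 48 h (a higher number here means that more compound is tolerated, a lower number that less compound is tolerated), compound 1 `CCCN(CCC)c1ccc(NC(=O)c2cc(Cl)ccc2O)c(Cl)c1` gives 10700 nM, compound 2 `O=C(Nc1ccc(NCc2ccc(O)cc2)cc1Cl)c1cc(Cl)ccc1O` gives 116000 nM and compound 3 `O=C(Nc1ccc(NCc2cccc(Br)n2)cc1Cl)c1cc(Cl)ccc1O` gives 92300 nM. Compound 3 thus stands within the scatter of compound 2 and well clear of compound 1, as shown by an 8.6-fold higher number from compound 1 to compound 3 (0.94 log units; beyond the scatter).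

Compound 4 `O=C(Nc1ccc(NCc2ccc(Br)s2)cc1Cl)c1cc(Cl)ccc1O` carries 5-bromothiophen-2-yl in place of 6-bromopyridin-2-yl on a saturated chain carbon bound to a nitrogen on an aromatic ring.

Within the data shown here, the closest precedent is the exchange at the same place, a 1.3-fold lower number from compound 2 to compound 3 (0.10 log units; within the scatter), which stayed within the scatter. The much larger an 11-fold higher number from compound 1 to compound 2 (1.04 log units; beyond the scatter) replaced dipropylamino, a different kind of change. No step beyond the scatter is therefore expected in this assay. The expected step is a 1.2-fold lower number from compound 3 to compound 4 (0.06 log units; within the scatter). Compound 4 is estimated at 80000 nM, within a range of 35000 nM to 170000 nM.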

Compound 4, half-maximal cytotoxic concentration: 20700 nM
For compound 4 the middle estimate is 3.9-fold (0.59 log units) above the measured one; measured number outside the range, below it.
By their numbers in this assay, from the lowest: compounds 1 and 4 (each within the scatter of the next); then compounds 3 and 2 (each within the scatter of the next).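

In this assay the ring on this saturated chain carbon turns out not to be freely exchangeable: there is a 4.5-fold lower number from compound 3 to compound 4 (0.65 log units; beyond the scatter) and also a 5.6-fold lower number from compound 2 to compound 4 (0.75 log units; beyond the scatter) even though the earlier exchange at this place stayed within the scatter. With a 1.9-fold higher number from compound 1 to compound 4 (0.29 log units; within the scatter) the clear separation from dipropylamino that compound 2 and compound 3 showed is gone for 5-bromothiophen-2-yl. Nothing at hand explains this difference between the two rings.

From the compounds shown here alone, whether the shift belongs to the thiophene ring itself or to its bromine stays open, as an unsubstituted thiophen-2-yl or a 5-chlorothiophen-2-yl at this place would be needed to separate the two.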